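Halogen swap on the sulfonyl aryl group: compound 4

This account rests on a few compounds, and the source may have more. Where it says the series, first, only, none or still open, it means among the compounds named here.

Compound 1 `COc1ccc(-c2cc(=O)c3c(OC)cc(OC)cc3n2Cc2ccccc2)cc1` carries a benzyl group on the ring nitrogen of the shared core; in a functional assay on HepG2 cells (Homo sapiens) for antiproliferative activity, with a stated time of 72 h (a lower number here means that less compound is needed, a higher number that more compound is needed for the effect), compound 1 reaches only a limit, > 17300 nM. Compound 2 `COc1ccc(-c2cc(=O)c3c(OC)cc(OC)cc3n2S(=O)(=O)c2ccc(C=O)cc2)cc1` has a (4-formylphenyl)sulfonyl group in its place, and in this assay compound 2 shows a limit, > 34400 nM. Compound 3 `COc1ccc(-c2cc(=O)c3c(OC)cc(OC)cc3n2S(=O)(=O)c2ccc(F)cc2)cc1` bears a (4-fluorophenyl)sulfonyl group; in this assay compound 3 gives a limit, > 65500 nM. The steps a step that the two limits leave unreadable from compound 1 to compound 2, a step that the two limits leave unreadable from compound 1 to compound 3 and a step that the two limits leave unreadable from compound 2 to compound 3 stay unreadable, and compound 3 stands at one of three limits, with the limit of > 65500 nM in this assay, at which 1 of the 3 values shown sits, being its own. Compound 4 `COc1ccc(-c2cc(=O)c3c(OC)cc(OC)cc3n2S(=O)(=O)c2ccc(Br)cc2)cc1` differs from compound 3 by bromo in place of fluoro on an aromatic carbon. Within the data shown here, no measured step bears on this change, so no direction can be read. Compound 4 is expected to remain at a limit, estimated near 70000 nM (range 30000 nM to 150000 nM). The expected step is a step that the limit leaves unreadable from compound 3 to compound 4.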

Compound 4, half-maximal effective concentration: 16300 nM
Compound 4: the middle estimate sits 4.3-fold (0.63 log units) above what was measured; the whole stated range lies above it.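

In this assay, among these compounds, this carbon of the sulfonyl aryl ring is sensitive to the group it carries: bromo in place of fluoro gives an at least 4.0-fold lower number from compound 3 to compound 4 (0.60 log units; beyond the scatter) and is the first step that can be read. Bromo in place of formyl gives an at least 2.1-fold lower number from compound 2 to compound 4 (0.32 log units; beyond the scatter) in the same direction. The step of an at least 1.0-fold lower number from compound 1 to compound 4 (0.02 log units; that floor lies within the scatter) leaves the comparison with the benzyl group on the ring nitrogen unsettled.

Going by these compounds, whether chloro, iodo or an amine at this carbon would hold or extend the gain remains open. The data shown give no cause for the effect of bromo.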